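The source may report more compounds than this note shows. Statements on the series, on what has been measured and on what is new or still open speak of the compounds shown alone.

Compound 1 `Cc1ccc2c(C3CCN(CCN4CCN(C(C)C)C4=O)CC3)cn(-c3ccc(F)cc3)c2c1` gives 7.3 umol/kg
Compound 2 `CC(C)N1CCN(CCN2CCC(c3cn(-c4ccc(F)cc4)c4cc(Cl)ccc34)CC2)C1=O` gives 2 umol/kg

Both numbers come from a functional assay on the whole organism for inhibition, with Mus musculus as the target, with a stated time of 180 s (on this read-out lower numbers stand for an effect already at smaller amounts and higher numbers for an effect only at larger amounts of compound), and compound 1 holds the higher of the two, so it needs the larger dose. Compound 3 `Cc1ccc2c(C3CCN(CCN4CCN(C(C)C)C4=O)CC3)cn(-c3ccccc3)c2c1` keeps the core of compound 1 and changes in one place, 4-fluorophenyl to phenyl: hydrogen in place of fluoro on an aromatic carbon is the whole difference. For the measured compounds named here, only one measured step exists, a 3.7-fold lower number from compound 1 to compound 2 (0.56 log units; beyond the scatter), and it swaps chloro for methyl, not fluoro for hydrogen. That step shows that a single small swap in this series can move the number modestly, but it gives no direction for the loss of fluoro. No step beyond the scatter is therefore expected, though a modest one either way remains possible. The expected step is a 1.2-fold higher number from compound 1 to compound 3 (0.09 log units; within the scatter), a small one. For compound 3 the estimate is 9 umol/kg, with an expected range of 3 umol/kg to 27 umol/kg.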

Compound 3, dose for half-maximal effect: > 11 umol/kg
Compound 3: a limit, no number; the forecaster's own chance of this, stated with the estimate: 5%; middle value at least 1.2-fold (0.08 log units) from the limit.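

Compound 3 is reported only as a limit, not as a number: the limit of > 11 umol/kg in this assay, at which 1 of the 3 values shown sits.

In this assay, for the compounds shown here, this is the first view of the place on an aromatic carbon para to a large group, and replacing fluoro with hydrogen there gives an at least 1.5-fold higher number from compound 1 to compound 3 (0.17 log units; that floor lies within the scatter). Going by these compounds, the direction runs toward a larger dose, with no sign that hydrogen does better than fluoro, but the floor of this step cannot establish a real loss, and the true size of the step remains unknown.

On these data alone, what stays open is how chloro, a methoxy group or an amine would read in this same place on the phenyl ring. Also open, as far as these compounds go, is whether losing fluoro would give a similar step with the chloro of compound 2 on the shared core.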